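The compounds below may be only part of what the source reports. "The series", "measured", "known", "first", "only" and "open" are said of these compounds alone.

Measured in a functional assay on HCC1806 cells (Homo sapiens) for inhibition, read by sulforhodamine B assay, tested at 10 uM; on this read-out lower numbers stand for less inhibition and higher numbers for more inhibition at the one concentration tested (going by the name of the read-out):

- compound 1 `CN1CCN(c2ccc(C3=NNC(c4ccc(N(C)C)cc4)C3)cc2)CC1` gives 31.2%
- compound 2 `CN1CCN(c2ccc(C3=NN(C(=O)c4ccc(C(F)(F)F)cc4)C(c4ccc(N(C)C)cc4)C3)cc2)CC1` gives 84.1%
- compound 3 `CN1CCN(c2ccc(C3=NN(C(=O)/C=C/c4ccccc4)C(c4ccc(N(C)C)cc4)C3)cc2)CC1` gives 71%

Compound 3 stands second highest of the three numbers. Its nearest neighbour is compound 2, the number being a number 13.1 percentage points lower from compound 2 to compound 3 (beyond the scatter); its furthest is compound 1, the number being a number 39.8 percentage points higher from compound 1 to compound 3 (beyond the scatter).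

Compound 4 `CN1CCN(c2ccc(C3=NN(S(C)(=O)=O)C(c4ccc(N(C)C)cc4)C3)cc2)CC1` is still to be measured in this assay. Its change from compound 3 is methylsulfonyl in place of (2-phenylethenyl)carbonyl on an amine nitrogen in a ring.

For the measured compounds named here, two measured steps bear on the same position. Replacing the hydrogen on the ring amine nitrogen by an acyl group gave a number 52.9 percentage points higher from compound 1 to compound 2 (beyond the scatter) and a number 39.8 percentage points higher from compound 1 to compound 3 (beyond the scatter), both large. Exchanging one acyl group for another gave a number 13.1 percentage points lower from compound 2 to compound 3 (beyond the scatter), modest. Going by the values given here, no measured step covers a sulfonyl group on that nitrogen, so the size of the effect of a methylsulfonyl there is not anchored. The acylated compounds 2 and 3 both give numbers far above that of compound 1, so substitution on this nitrogen has so far gone with a higher number, but the methylsulfonyl group is the smallest substituent yet tried there, so a drop from compound 3 is expected, a number 16 percentage points lower from compound 3 to compound 4 (beyond the scatter), with wide uncertainty. Compound 4 is estimated at 55%, between 30% and 80%.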

Compound 4, a percentage reported as inhibition, at one concentration (the size of the read-out at that concentration, not a potency): -18.5%
Compound 4: middle estimate off by 73.5 percentage points, on the high side; the whole stated range lies above it.
By their numbers in this assay, from the lowest: compound 4; then compound 1; then compound 3; then compound 2.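

In this assay, substitution on the amine nitrogen in a ring no longer goes with a higher number: methylsulfonyl in place of hydrogen gives a number 49.7 percentage points lower from compound 1 to compound 4 (beyond the scatter), opposite in direction to the two carbonyl-linked groups, which give a number 52.9 percentage points higher from compound 1 to compound 2 (beyond the scatter) and a number 39.8 percentage points higher from compound 1 to compound 3 (beyond the scatter). The outcome at this position therefore depends strongly on which group is attached: methylsulfonyl in place of the carbonyl-linked groups gives a number 89.5 percentage points lower from compound 3 to compound 4 (beyond the scatter) and a number 102.6 percentage points lower from compound 2 to compound 4 (beyond the scatter), both large, whereas exchanging one carbonyl-linked group for the other gives only a number 13.1 percentage points lower from compound 2 to compound 3 (beyond the scatter), and compound 4, at -18.5%, is the only one of the four with a negative number. Nothing available on these compounds accounts for this reversal.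

The compounds shown leave open whether the low number goes with the sulfonyl link itself or with the loss of the aromatic ring carried by the groups in compound 2 and compound 3. A phenylsulfonyl group and an acetyl group on the same nitrogen would separate these two readings.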